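Compound 3: cyano in place of carbamoyl

The compounds below may be only part of what the source reports. "The series", "measured", "known", "first", "only" and "open" are said of these compounds alone.

Compound 1 `N#Cc1c(N)n(COCc2ccccc2)c2ncnc(N)c12`: 118000 nM
Compound 2 `COCCOCn1c(N)c(C(N)=O)c2c(N)ncnc21`: > 100000 nM
Compound 3 `COCCOCn1c(N)c(C#N)c2c(N)ncnc21`: not yet measured

All readings come from a functional assay on KB cells (Homo sapiens) for inhibition; a lower number here means a stronger inhibitor, a higher number a weaker inhibitor. Compound 2 stands at > 100000 nM, which is a limit and not a number. The change to compound 3 is cyano in place of carbamoyl on an aromatic carbon. Within the data shown here, no measured pair shows this change. Among the measured compounds shown here, the only numbered reading is that of compound 1 at 118000 nM, so no large gain is expected in this assay. The expected at least 1.1-fold lower number from compound 2 to compound 3 (0.04 log units; that floor lies within the scatter) stays within the scatter. For compound 3 the estimated value is 90000 nM, with an expected range of 30000 nM to 200000 nM.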

Compound 3, half-maximal inhibitory concentration: 210000 nM
For compound 3 the middle estimate is 2.3-fold (0.37 log units) below the measured one, and the stated range ends below it.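

In this assay compound 3 gives a numbered reading for cyano on this aromatic carbon with the (2-methoxyethoxy)methyl group in place. Methoxymethyl in place of phenyl on the chain gives a 1.8-fold higher number from compound 1 to compound 3 (0.25 log units; within the scatter), so the two chains are not told apart in this series. The step from carbamoyl to cyano cannot be read, because compound 2 is recorded only as a limit: the limit of > 100000 nM in this assay, at which 1 of the 3 values shown sits.

Still open, as far as these compounds go, is whether a carboxylic acid or an amine on this aromatic carbon would give a clearly lower number in this assay. Also open, from the compounds shown here alone, is how a longer chain in place of the (2-methoxyethoxy)methyl group would read.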